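Chloro in place of hydrogen on a pyridine ring

This account rests on a few compounds, and the source may have more. Where it says the series, first, only, none or still open, it means among the compounds named here.

Measured compounds:
- compound 1 `c1ccc(NCc2ccc(CNc3ccccc3)cc2)cc1`: 64%
- compound 2 `Fc1ccc(NCc2ccc(CNc3ccc(F)cn3)cc2)nc1`: 68%
- compound 3 `c1ccc(NCc2ccc(CNc3ncccn3)cc2)nc1`: 64%

Of the compounds shown here, three sharing one core have been tested in a functional assay on MDA-MB-231 cells for antagonist activity at C-X-C chemokine receptor type 4 (Homo sapiens), tested at 100 nM; on this read-out higher numbers stand for a stronger effect at the one concentration tested and lower numbers for a weaker effect. In this assay compound 1 gives 64%, compound 2 gives 68% and compound 3 gives 64%. Compound 3 stands level with compound 1 at the digits shown, the two together being the lowest of the three numbers, and compound 2 differs from them by a gap that lies within the usual scatter of such measurements. All three values are therefore best read as one level.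

The next compound, compound 4 `Clc1ccc(NCc2ccc(CNc3ncccn3)cc2)nc1`, differs from compound 3 in a single place: chloro in place of hydrogen on an aromatic carbon, so that pyridin-2-yl becomes 5-chloropyridin-2-yl. Within the data shown here, no pair of measured compounds differs by exactly this change, so no measured step can be used as a guide. Because compound 2, which also carries halogen on its pyridine rings, gives 68% in this assay, a level close to compound 3, the step is expected to be small; the expected step is a number 2 percentage points higher from compound 3 to compound 4 (within the scatter), which is no change beyond the scatter. For compound 4 the estimated value in this assay is 66%, with a likely range from 52% to 80%.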

Compound 4, a percentage reported as inhibition, at one concentration (the size of the read-out at that concentration, not a potency): 100%
Compound 4: the middle estimate sits 34 percentage points below what was measured, and the stated range ends below it.
By their numbers in this assay, from the lowest: compounds 1, 3 and 2 (each within the scatter of the next); then compound 4.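

Putting a single chloro on the pyridin-2-yl ring, two atoms from the ring nitrogen, gives a number 36 percentage points higher from compound 3 to compound 4 (beyond the scatter) in this assay and so shows that this position of the shared core is not indifferent to what it carries. Among these compounds, the earlier compounds differ from one another in more than one place, so this pair is the first to isolate the effect of one small change. Nothing measured here explains the size of the step.

From the compounds shown here alone, it remains open whether the gain is specific to chloro or would also appear with bromo, methyl or methoxy at this position, and whether an amine or a carboxylic acid would be tolerated there. Going by these compounds, the read-out comes from one concentration, so the potency of compound 4 also remains open.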